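A few compounds are considered here, and "the series" means these few. Any claim that something is new, unique, unknown or untested is made for them only; others in the source may bear on it.

In an ADME assay on MDCK cells (Canis lupus familiaris) for cytotoxicity, read by MTT assay, with a stated time of 72 h (a higher number here means a weaker inhibitor, a lower number a stronger inhibitor), compound 1 `COc1ccc(/C=C/C(=O)CC(C)=O)cc1` gives 41600 nM. Compound 2 `COc1ccc(/C=C/c2cc(C)no2)cc1` gives 70200 nM in this assay, and compound 3 `Cc1cc(/C=C/c2ccc(O)cc2)on1` gives 58300 nM. The difference between the core of compound 1 and the core of compound 2 is not broken down here. Compound 3 carries the change hydrogen in place of methyl on an oxygen on an aromatic ring relative to compound 2, and the measured step of a 1.2-fold lower number from compound 2 to compound 3 (0.08 log units; within the scatter) is recorded. Compound 4 `CC(=O)CC(=O)/C=C/c1ccc(O)cc1` carries the same change from compound 1, namely (hydrogen in place of methyl on an oxygen on an aromatic ring), at a place described in the same words. In this assay the step of a 1.2-fold lower number from compound 1 to compound 4 (0.06 log units; within the scatter) is expected to be of a similarly modest size, because the step of a 1.2-fold lower number from compound 2 to compound 3 (0.08 log units; within the scatter) stayed within the scatter of the method. Compound 4 is therefore estimated at 36000 nM, with a likely range from 20000 nM to 70000 nM.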

Compound 4, half-maximal inhibitory concentration: 30600 nM
Beside the measured number, compound 4's estimate is 1.2-fold (0.07 log units) above it; the range from low to high includes it.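

In this assay the change from methoxy to hydroxy gives a 1.4-fold lower number from compound 1 to compound 4 (0.13 log units; within the scatter) and so stays small on this second core. Set side by side, the two steps do not differ: the same change on two cores in this assay, a 1.2-fold lower number (0.08 log units; within the scatter) from compound 2 to compound 3 and a 1.4-fold lower number (0.13 log units; within the scatter) from compound 1 to compound 4, 1.1-fold (0.05 log units) apart, within the scatter of two such steps. The change therefore carries from one core to the other without a readable difference, but with both steps within the scatter, this shows only that it does little on either core, not that the two cores would respond alike to a change with a larger effect.

The compounds shown carry only methoxy or hydroxy at this place on the aromatic ring. Going by these compounds, how a longer chain on that oxygen, or an amine in place of the hydroxy, would read remains open.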